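Fluoro for methoxy on the anilino ring of compound 3

The source may report more compounds than this note shows. Statements on the series, on what has been measured and on what is new or still open speak of the compounds shown alone.

Compound 1 `COc1ccc(NC2=CC(=O)c3c(nc4n3[C@H]3OC[C@@H](O)[C@H]3OC4)C2=O)cc1` gives 4470 nM in a functional assay on MCF7 cells (Homo sapiens) for inhibition, read by sulforhodamine B assay; on this read-out lower numbers stand for stronger inhibition and higher numbers for weaker inhibition. Compound 2 `CCOc1ccc(NC2=CC(=O)c3c(nc4n3[C@H]3OC[C@@H](O)[C@H]3OC4)C2=O)cc1` reaches only the limit of > 4000 nM in this assay, so no number is known for it. Within the data shown here, compound 3 `COc1ccccc1NC1=CC(=O)c2c(nc3n2[C@H]2OC[C@@H](O)[C@H]2OC3)C1=O` gives 6580 nM in this assay; it holds the higher of the two numbers known so far, its nearest neighbour being compound 1 with a 1.5-fold higher number from compound 1 to compound 3 (0.17 log units; within the scatter), a gap within the scatter. The steps a step that the limit leaves unreadable from compound 1 to compound 2 and a step that the limit leaves unreadable from compound 2 to compound 3 stay unreadable because of the limit of > 4000 nM in this assay, at which 1 of the 3 values shown sits.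

Compound 4 `O=C1C(Nc2ccccc2F)=CC(=O)c2c1nc1n2[C@H]2OC[C@@H](O)[C@H]2OC1` differs from compound 3 in one place: fluoro in place of methoxy on an aromatic carbon. Among the measured compounds shown here, no measured step exchanges methoxy for fluoro. For the measured compounds named here, the only readable step, 2-methoxyphenyl in place of 4-methoxyphenyl in a 1.5-fold higher number from compound 1 to compound 3 (0.17 log units; within the scatter), stays within the scatter, so the series gives no ground for a step beyond the scatter here. The expected step is therefore a 1.1-fold higher number from compound 3 to compound 4 (0.03 log units; within the scatter), no more than the scatter. For compound 4 the estimate in this assay is 7000 nM, with a range from 2500 nM to 20000 nM.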

Compound 4, half-maximal inhibitory concentration: > 4000 nM
Compound 4: only a limit was reported; the forecaster's own chance of this, stated with the estimate: 25%; the middle value is on the limit's open side.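

Compound 4 gives only a limit in this assay, > 4000 nM. Its steps from compound 1, compound 2 and compound 3 cannot be read. Still open, as far as these compounds go, is whether fluoro in place of methoxy on an aromatic carbon moves compound 4 away from compound 3 at all.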